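From 4-methylphenyl to phenyl

A few compounds are considered here, and "the series" means these few. Any claim that something is new, unique, unknown or untested is made for them only; others in the source may bear on it.

Compound 3 (`Cc1ccc(NC(=O)C2(C(=O)Nc3ccc(Nc4ncc5cc(C(=O)N(C)C)n(C6CCCC6)c5n4)cc3)CC2)cc1`) carries a (4-methylphenyl)carbamoyl group and gives 80.6% in a functional assay on OVCAR-5 cells (Homo sapiens) for inhibition, read by CCK-8 assay, with a stated time of 72 h, tested at 10 uM (on this read-out lower numbers stand for less inhibition of growth and higher numbers for more inhibition of growth at the one concentration tested), on the single concentration tested. Its fluoro analogue, compound 1 (`CN(C)C(=O)c1cc2cnc(Nc3ccc(NC(=O)C4(C(=O)Nc5ccc(F)cc5)CC4)cc3)nc2n1C1CCCC1`), gives 79.7% and its chloro analogue, compound 2 (`CN(C)C(=O)c1cc2cnc(Nc3ccc(NC(=O)C4(C(=O)Nc5ccc(Cl)cc5)CC4)cc3)nc2n1C1CCCC1`), gives 85.3% in this assay as well. All three values lie within the scatter of one another, so compound 3 sits inside that cluster, closest to compound 1 and furthest from compound 2, with no order that the data would support. Methyl in place of fluoro gives a number 0.9 percentage points higher from compound 1 to compound 3 (within the scatter) and methyl in place of chloro gives a number 4.7 percentage points lower from compound 2 to compound 3 (within the scatter) at the same place. Compound 4 (`CN(C)C(=O)c1cc2cnc(Nc3ccc(NC(=O)C4(C(=O)Nc5ccccc5)CC4)cc3)nc2n1C1CCCC1`) has not yet been measured and has hydrogen in place of methyl on an aromatic carbon. For the measured compounds named here, no measured compound has hydrogen at this place, so these steps bear on the change only indirectly. The widest of them is a number 5.6 percentage points higher from compound 1 to compound 2 (within the scatter) and so no step beyond the scatter is expected in this assay here. The estimated change is a number 1.6 percentage points lower from compound 3 to compound 4 (within the scatter) and it is expected to stay within the scatter. The estimate for compound 4 is 79% with 68% to 88% as its expected range.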

Compound 4, percent growth inhibition at one concentration: 77.1%
Estimate against measurement, compound 4: 1.9 percentage points above, and the stated range covers the measured number.
By their numbers in this assay, from the lowest: compounds 4, 1, 3 and 2 (each within the scatter of the next).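

Hydrogen in place of methyl gives a number 3.5 percentage points lower from compound 3 to compound 4 (within the scatter), hydrogen in place of chloro gives a number 8.2 percentage points lower from compound 2 to compound 4 (within the scatter), and hydrogen in place of fluoro gives a number 2.6 percentage points lower from compound 1 to compound 4 (within the scatter). The earlier compounds shown here compared only substituted rings, whereas these steps add the unsubstituted phenylcarbamoyl group as a point of reference: in this assay compound 4 stays within the scatter of all three analogues, so none of the methyl, fluoro or chloro groups on this aromatic carbon, para to a large group, is needed to keep the number in that cluster. No available evidence gives a reason for this flat picture.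

The compounds shown leave open whether a carboxylic acid, an amine, a methoxy group or a longer chain at this place would stay within the same cluster or move clearly away from it. They also leave open whether the four compounds, which cannot be told apart at the one concentration tested, would separate in a full concentration-response comparison.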